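Adding a second sulfate to a disaccharide binder

The source may hold more compounds than are shown below. What is called first, only, known or untested is meant among the compounds shown, and "the series" means these compounds.

Compound 1 `CC(=O)N[C@H]1[C@@H](OC[C@@H](O)[C@@H](O)[C@H](O)[C@@H](O)CNc2cccc(NC(=O)CCCCC3CCSS3)c2)O[C@H](CO)[C@H](OS(=O)(=O)O)[C@@H]1O[C@@H]1O[C@H](C(=O)O)[C@@H](O)[C@H](O)[C@H]1OS(=O)(=O)O` — in an assay on isolated protein for binding affinity to fibroblast growth factor 2 (Homo sapiens), read by surface plasmon resonance (on this read-out higher numbers stand for weaker binding and lower numbers for tighter binding), compound 1 gives 41 nM
Compound 2 `CC(=O)N[C@H]1[C@@H](OC[C@@H](O)[C@@H](O)[C@H](O)[C@@H](O)CNc2cccc(NC(=O)CCCCC3CCSS3)c2)O[C@H](COS(=O)(=O)O)[C@H](O)[C@@H]1O[C@@H]1O[C@H](C(=O)O)[C@@H](O)[C@H](O)[C@H]1OS(=O)(=O)O` — in this assay compound 2 gives 23 nM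

Two measured compounds share one core and differ only in which oxygen carries the sulfate. In this assay compound 2 has the lower of the two numbers, but its gap to compound 1 lies within the usual scatter, so the two cannot be ranked against each other.

Compound 3 `CC(=O)N[C@H]1[C@@H](OC[C@@H](O)[C@@H](O)[C@H](O)[C@@H](O)CNc2cccc(NC(=O)CCCCC3CCSS3)c2)O[C@H](COS(=O)(=O)O)[C@H](OS(=O)(=O)O)[C@@H]1O[C@@H]1O[C@H](C(=O)O)[C@@H](O)[C@H](O)[C@H]1OS(=O)(=O)O` has not yet been measured. It is reached from compound 2 by one change: sulfo in place of hydrogen on an oxygen on a saturated carbon. In other words, compound 3 carries the sulfate of compound 2 and the sulfate of compound 1 together.

Within the data shown here, no step between measured compounds is known here, so the size of this change must be guessed. Each single sulfate alone gives tight binding; a second one is expected to tighten binding modestly, by a 1.9-fold lower number from compound 2 to compound 3 (0.28 log units; within the scatter). Compound 3 is therefore estimated at 12 nM, within a range of 4 nM to 40 nM.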

Compound 3, dissociation constant: 21 nM
For compound 3 the middle estimate is 1.8-fold (0.24 log units) below the measured one; low and high end bracket the measured number.
By their numbers in this assay, from the lowest: compounds 3, 2 and 1 (each within the scatter of the next).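

In this assay, sulfo in place of hydrogen on an oxygen on a saturated carbon gives a 1.1-fold lower number from compound 2 to compound 3 (0.04 log units; within the scatter) and a 2.0-fold lower number from compound 1 to compound 3 (0.29 log units; within the scatter), and both steps lie within the scatter. Compound 3 carries both sulfates, yet its binding cannot be told apart from that of compound 1 or compound 2. The earlier pair showed only that the sulfate could sit on either oxygen; this result adds that, on these numbers, the two together bring no readable gain over either one alone.

From the compounds shown here alone, it remains open whether a phosphate in place of either sulfate, or a longer chain on the shared core, would shift the number beyond the scatter. No measurement shown here bears on why the steps are this small.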